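The compounds below may be only part of what the source reports. "The series", "measured", "known", "first", "only" and "open" are said of these compounds alone.

In a functional assay for inhibition, with Homo sapiens as the target (a lower number here means a stronger inhibitor, a higher number a weaker inhibitor), the measured compounds stand as follows.
Compound 1 `CCc1nc(C)c2cnnc(SC)n12` gives > 48000 nM, which is a limit of the assay rather than a number.
Compound 2 `CCCc1nc(C)c2cnnc(SC)n12` gives > 48000 nM, again a limit of the assay.
Compound 3 `CCc1nc(C)c2cnn(CC)c(=O)n12` gives 75600 nM.

Among the compounds with values here, compound 3 thus gives the only number, while the two other values sit at a limit (the limit of > 48000 nM in this assay, at which 2 of the 3 values shown sit). The step from compound 1 to compound 2 is a step that the two limits leave unreadable from compound 1 to compound 2, because the limit of > 48000 nM in this assay, at which 2 of the 3 values shown sit, holds for both ends. The difference between the core of compound 1 and the core of compound 3 is not broken down here.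

Compound 4 `CCn1ncc2c(C)nc(C(C)C)n2c1=O` has not yet been measured. It differs from compound 3 by methyl in place of hydrogen on a saturated chain carbon bound to an aromatic carbon and a saturated chain carbon. The same kind of change was made from compound 1 to compound 2, but there the methyl entered on a saturated chain carbon, two bonds along the chain from an aromatic carbon, whereas in compound 4 it enters on a saturated chain carbon bound to an aromatic carbon and a saturated chain carbon. Within the data shown here, since the only measured instance of this kind of change reads a step that the two limits leave unreadable from compound 1 to compound 2, no size can be taken from it, and the expectation rests on compound 3 itself giving 75600 nM. The expected step from compound 3 to compound 4 is therefore a 1.1-fold lower number from compound 3 to compound 4 (0.03 log units; within the scatter). Compound 4 is estimated at 70000 nM, expected to fall between 20000 nM and 250000 nM.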

Compound 4, half-maximal inhibitory concentration: > 48000 nM
Compound 4 ended at the assay's limit; the forecaster's own chance of this, stated with the estimate: 40%; the middle value is on the limit's open side.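

Compound 4 gives > 48000 nM as a limit of the assay and not a number. The step from compound 3 to compound 4, ethyl to isopropyl, therefore cannot be read: the limit of > 48000 nM in this assay, at which 3 of the 4 values shown sit. The compounds shown leave open whether any change to these structures gives a stronger inhibitor than compound 3.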